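Saphenous vein series: ester in place of the aldehyde

The source may hold more compounds than are shown below. What is called first, only, known or untested is meant among the compounds shown, and "the series" means these compounds.

Measured so far:
compound 1, `COc1ccc(NC(=O)c2ccc(-c3ccc(C(=O)N(C)C)cc3C)cc2)cc1N1CCN(C)CC1`: 9.2
compound 2, `COc1ccc(C(=O)Nc2ccc(-c3ccc(C=O)cc3C)cc2)cc1CCCN(C)C`: 8.4

For the measured compounds named here, in a functional assay (Saphenous vein) with Canis familiaris (Canis lupus familiaris) as the target (a higher number here means a more potent compound, by a factor of ten per unit of this negative logarithm, a lower number a less potent compound), compound 1 gives 9.2 and compound 2 gives 8.4; compound 2 stands lower of the two, the gap being beyond the scatter, and no single-point step links them.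

Compound 3, `COCCOC(=O)c1ccc(-c2ccc(NC(=O)c3ccc(OC)c(CCCN(C)C)c3)cc2)c(C)c1`, is not yet measured. From compound 2 it differs by 2-methoxyethoxy in place of hydrogen on a carbonyl carbon. Going by the values given here, no measured step covers this change, so the expected step of a number 0.20 log units higher from compound 2 to compound 3 (within the scatter) is small, not beyond the scatter in either direction. Compound 3 is accordingly expected at about 8.6, within 8 to 9.2.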

Compound 3, negative logarithm of the antagonist equilibrium constant: 8.4
Compound 3: middle estimate off by 0.20 log units, on the high side; low and high end bracket the measured number.
By their numbers in this assay, from the lowest: compounds 2 and 3 (each within the scatter of the next); then compound 1.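

In this assay, for the compounds shown here, the swap of formyl for (2-methoxyethoxy)carbonyl gives no change at the digits printed from compound 2 to compound 3 (within the scatter) and is the first step read at this position. On this carbonyl carbon, then, a hydrogen can give way to 2-methoxyethoxy, with its 5 heavy atoms, and the number stays within the scatter. No available evidence explains this result.

Still open, from the compounds shown here alone, is whether a carboxylic acid or a methyl ester on this carbonyl carbon holds the number. The same question applies to a chain longer than 2-methoxyethoxy.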